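Chloro on compound 2: a small step expected

The compounds below may be only part of what the source reports. "The series", "measured", "known", "first", "only" and "open" are said of these compounds alone.

Measured in a functional assay on HeLa cells (Homo sapiens) for cytotoxicity, read by MTT assay, with a stated time of 48 h; on this read-out higher numbers stand for weaker inhibition and lower numbers for stronger inhibition:
- compound 1 `COc1ccc(-c2nc3ccccn3c2C(=O)/C=C\Nc2ccc3ncccc3c2)cc1`: 4850 nM
- compound 2 `O=C(/C=C\Nc1cnc2ccccc2c1)c1c(-c2ccccc2)nc2ccccn12`: 3080 nM
- compound 3 `COc1cc(N/C=C\C(=O)c2c(-c3ccc(Cl)cc3)nc3ccccn23)cc(OC)c1OC`: 3020 nM

These three values all lie within the usual scatter of one another, so repeated measurements could not reliably tell them apart. Compound 2, at 3080 nM, therefore sits in one band with the other two, and no ranking among them can be claimed.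

The next compound is compound 4 `O=C(/C=C\Nc1cnc2ccccc2c1)c1c(-c2ccc(Cl)cc2)nc2ccccn12`. It comes from compound 2 through a single change: chloro in place of hydrogen on an aromatic carbon. Put simply, this is chloro in place of hydrogen on an aromatic carbon, turning phenyl into 4-chlorophenyl. Within the data shown here, no pair of measured compounds shows this change on its own, so the data give no direct size for it. The nearest hint is compound 3, which also carries a 4-chlorophenyl group and gives 3020 nM, inside the same band. This is thin evidence, but it gives no reason to expect a large shift in this assay.

The estimated step is a 1.1-fold lower number from compound 2 to compound 4 (0.06 log units; within the scatter), and it is expected to stay within the scatter, with no firm direction. Compound 4 is expected at 2700 nM, with an estimated range from 1100 nM to 6000 nM.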

Compound 4, half-maximal inhibitory concentration: 3720 nM
For compound 4 the middle estimate is 1.4-fold (0.14 log units) below the measured one; measured number inside the range.
By their numbers in this assay, from the lowest: compounds 3, 2, 4 and 1 (each within the scatter of the next).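

In this assay the change from phenyl to 4-chlorophenyl gives a 1.2-fold higher number from compound 2 to compound 4 (0.08 log units; within the scatter) and is the only direct reading of this change among the compounds shown. At this spot, on an aromatic carbon para to a large group, swapping hydrogen for chloro therefore leaves the number inside the band that repeated measurements could not split, so this single pair reveals no measurable effect of the chloro group on cytotoxicity in these cells. No separate measurement is available that could explain the result, whether through a property of the chloro group or through how these compounds act on the cells.

On these data alone, it remains open whether a quite different group on the same ring carbon, such as an amine or a carboxylic acid, would move the number beyond the scatter. It is also open whether chloro would behave the same way with another group on the far side of the molecule: compound 3 carries the same 4-chlorophenyl group, but it has no phenyl partner among the compounds shown, so the change rests on one pair.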